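Amide aryl swap on the aminoquinoline series: compound 4

The source may hold more compounds than are shown below. What is called first, only, known or untested is meant among the compounds shown, and "the series" means these compounds.

Compound 1 `CCc1ccc(C(=O)Nc2ccc3nc(N4CCN(CC)CC4)cc(C)c3c2)cc1`: 3060 nM
Compound 2 `Cc1cc(N2CCCCC2)nc2ccc(NC(=O)c3ccc(Cl)c(Cl)c3)cc12`: 31100 nM
Compound 3 `CNc1cc(C)c2cc(NC(=O)c3ccc(Cl)c(Cl)c3)ccc2n1`: 2520 nM

In a functional assay on MCF7 cells (Homo sapiens) for antiproliferative activity, read by MTT assay, with a stated time of 72 h (on this read-out higher numbers stand for weaker inhibition and lower numbers for stronger inhibition), compound 1 gives 3060 nM, the second highest of the three numbers; compound 3 sits within the scatter of it, and compound 2 lies well above. For the measured compounds named here, the one measured step, a 12-fold lower number from compound 2 to compound 3 (1.09 log units; beyond the scatter), concerns the amine on the shared core, not the amide side. Compound 4 `CCN1CCN(c2cc(C)c3cc(NC(=O)c4ccc[nH]4)ccc3n2)CC1` differs from compound 1 by 1H-pyrrol-2-yl in place of 4-ethylphenyl on a carbonyl carbon. Going by the values given here, no measured pair touches the acyl group, so the step is unanchored and no direction beyond the scatter is expected. Compound 4 is therefore estimated at 4000 nM, range 1000 nM to 20000 nM, the expected step being a 1.3-fold higher number from compound 1 to compound 4 (0.12 log units; within the scatter).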

Compound 4, half-maximal inhibitory concentration: 14700 nM
Estimate against measurement, compound 4: 3.7-fold (0.57 log units) below; the measured number falls inside the stated range.
By their numbers in this assay, from the lowest: compounds 3 and 1 (each within the scatter of the next); then compound 4; then compound 2.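

The acyl side of the amide matters in this assay: 1H-pyrrol-2-yl in place of 4-ethylphenyl on a carbonyl carbon gives a 4.8-fold higher number from compound 1 to compound 4 (0.68 log units; beyond the scatter), whereas the earlier step concerned only the amine on the shared core. The change replaces a six-membered carbon ring bearing ethyl with a smaller five-membered ring carrying a hydrogen-bond donor, so several features change at once. No measured evidence bears on the cause of this step.

Which feature accounts for the step remains open. Unsubstituted phenyl, furan-2-yl or 1-methylpyrrol-2-yl on the same carbonyl carbon would help separate them.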